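Bromo for Carboxymethylamino on the Benzylic Ring

A few compounds are considered here, and "the series" means these few. Any claim that something is new, unique, unknown or untested is made for them only; others in the source may bear on it.

Compound 1 `O=[N+]([O-])c1cc(OCc2ccccc2)ccc1CNc1cc(C(F)(F)F)cc2[nH]ncc12` gives 97000 nM in an assay for inhibition of Tryptophan 2,3-dioxygenase (Homo sapiens), with stated times of 10 min and 60 min; a higher number here means a weaker inhibitor, a lower number a stronger inhibitor.
Compound 3 `O=[N+]([O-])c1ccccc1CNc1cc(Br)cc2[nH]ncc12` gives 39000 nM in this assay.
Compound 2 `O=C(O)CNc1cccc(CNc2cc(C(F)(F)F)cc3[nH]ncc23)c1` gives only a limit of the assay, > 100000 nM in this assay.

Compound 2 therefore stands at the top of the numbers shown, where one of the three values sits (the limit of > 100000 nM in this assay, at which 1 of the 3 values shown sits), and no number for it is known. Compound 4 `FC(F)(F)c1cc(NCc2cccc(Br)c2)c2cn[nH]c2c1` differs from compound 2 by one change: bromo in place of (carboxymethyl)amino on an aromatic carbon. Among the measured compounds shown here, no step between two measured compounds is recorded, so the size of this step cannot be read from the data. Compound 3 carries a bromo and a small nitro-bearing benzylic ring and gives a number, whereas compound 2 gives only a limit. The step is expected to run downward, an at least 2.0-fold lower number from compound 2 to compound 4 (0.30 log units; that floor lies within the scatter), beyond the scatter. Compound 4 is estimated at 50000 nM, between 15000 nM and 150000 nM.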

Compound 4, half-maximal inhibitory concentration: 19100 nM
The estimate for compound 4 lay 2.6-fold (0.42 log units) above the measured number; measured number inside the range.
By their numbers in this assay, from the lowest: compound 4; then compound 3; then compound 1. At a limit, above all of these: compound 2.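

Putting bromo in place of (carboxymethyl)amino on this aromatic carbon leads from a compound without a number to one with a number in this assay (an at least 5.2-fold lower number from compound 2 to compound 4 (0.71 log units; beyond the scatter)). Compound 2 stands at a limit of the assay, so this step gives only a floor: (the limit of > 100000 nM in this assay, at which 1 of the 4 values shown sits).

The compounds shown leave open whether bromo itself matters at this position, or whether chloro, methoxy or plain hydrogen would give a similar number. They also leave open how a simple amine, or a carboxylic acid on a longer chain, would read here.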